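The compounds below may be only part of what the source reports. "The series", "measured", "known", "first", "only" and "open" are said of these compounds alone.

In an in vivo ADME assay on the whole organism (strain 129/SvEvBrd x C57BL/6) for pharmacokinetics, with Mus musculus as the target, at a dose of 1 mg/kg by the intravenous route (on this read-out higher numbers stand for fast clearance and lower numbers for slow clearance), compound 2 `OC[C@@H](O)[C@@H](O)[C@H](O)c1c[nH]c(-c2cscn2)n1` gives 12.7 mL/min/kg. Among the compounds with values here, the only other measured compound, compound 1 `CC(O)c1nc([C@@H](O)[C@H](O)[C@H](O)CO)c[nH]1`, gives 16.4 mL/min/kg, so the two lie within the usual scatter of each other. The next structure, compound 3 `OC[C@@H](O)[C@@H](O)[C@H](O)c1c[nH]c(-c2cocn2)n1`, keeps the shared core and alters one group: 1,3-oxazol-4-yl in place of 1,3-thiazol-4-yl on an aromatic carbon. Put simply, 1,3-oxazol-4-yl takes the place of 1,3-thiazol-4-yl, and the entering ring has oxygen where the leaving ring has sulfur.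

Within the data shown here, no measured pair tests this exchange directly. Among the measured compounds shown here, the only measured step is an indirect guide. It involves a different exchange on the same aromatic carbon, with 1,3-thiazol-4-yl in place of 1-hydroxyethyl. With only a 1.3-fold lower number from compound 1 to compound 2 (0.11 log units; within the scatter) to go on, no step beyond the scatter is expected in this assay, and neither direction can be favoured. The estimated change is a 1.1-fold higher number from compound 2 to compound 3 (0.04 log units; within the scatter). The expected value for compound 3 is 14 mL/min/kg, with an estimated range from 7 mL/min/kg to 28 mL/min/kg.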

Compound 3, clearance: 16.6 mL/min/kg
The estimate for compound 3 lay 1.2-fold (0.07 log units) below the measured number, and the stated range covers the measured number.
By their numbers in this assay, from the lowest: compounds 2, 1 and 3 (each within the scatter of the next).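

In this assay, the exchange of 1,3-thiazol-4-yl for 1,3-oxazol-4-yl on the aromatic carbon between two ring nitrogen atoms gives a 1.3-fold higher number from compound 2 to compound 3 (0.12 log units; within the scatter), so replacing the sulfur of one ring with the oxygen of the other has no effect that can be told apart from ordinary measurement scatter. The same carbon also allows a comparison of 1,3-oxazol-4-yl with 1-hydroxyethyl, which gives a 1.0-fold higher number from compound 1 to compound 3 (0.01 log units; within the scatter); compounds 1, 2 and 3 therefore all lie within the scatter of one another, despite carrying an open-chain group or one of two aromatic rings at this position. No supporting measurement is available to explain this result.

The compounds shown leave open whether a quite different group on this carbon, such as an amine or a carboxylic acid, would produce a step beyond the scatter. On these data alone, the shared core also stays the same across all three compounds, so what its other parts, including the group of 8 heavy atoms, contribute to clearance remains unknown.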